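Chloro for trifluoromethyl on the pendant ring: cytotoxicity outlook

This account rests on a few compounds, and the source may have more. Where it says the series, first, only, none or still open, it means among the compounds named here.

Three measured compounds share one core and differ only in the pendant phenyl ring. Compound 1 `COc1ccc(-c2cc(C)c(Nc3ccnc(Nc4ccc(C#N)cc4)n3)c(C)c2)cc1` gives 2890 nM in an ADME assay on MT4 cells (Homo sapiens) for cytotoxicity, read by MTT assay, with a stated time of 4 days; on this read-out higher numbers stand for lower toxicity in this test and lower numbers for higher toxicity in this test. Compound 2 `COc1ccccc1-c1cc(C)c(Nc2ccnc(Nc3ccc(C#N)cc3)n2)c(C)c1` gives 940 nM in this assay. Compound 3 `Cc1cc(-c2ccccc2C(F)(F)F)cc(C)c1Nc1ccnc(Nc2ccc(C#N)cc2)n1` gives 4210 nM in this assay, the highest number of the three; the gap to compound 1 lies within the scatter, the gap to compound 2 beyond it. The measured steps read: a 3.1-fold lower number from compound 1 to compound 2 (0.49 log units; beyond the scatter); a 1.5-fold higher number from compound 1 to compound 3 (0.16 log units; within the scatter); a 4.5-fold higher number from compound 2 to compound 3 (0.65 log units; beyond the scatter).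

Compound 4 `Cc1cc(-c2ccccc2Cl)cc(C)c1Nc1ccnc(Nc2ccc(C#N)cc2)n1` has not been measured. The change from compound 3 is chloro in place of trifluoromethyl on an aromatic carbon. Among the compounds with values here, only one measured step swaps one group for another at this same place, a 4.5-fold higher number from compound 2 to compound 3 (0.65 log units; beyond the scatter), a modest move beyond the scatter; the move from 4-methoxyphenyl to 2-(trifluoromethyl)phenyl, a 1.5-fold higher number from compound 1 to compound 3 (0.16 log units; within the scatter), stayed within the scatter. Within the data shown here, no measured compound carries a chloro here, so the size of the new step has no direct precedent. Given that the two changes at this ring gave at most a modest shift, the expected step is small, a 1.4-fold lower number from compound 3 to compound 4 (0.15 log units; within the scatter). Compound 4 is therefore expected at 3000 nM in this assay, with a range of 1200 nM to 7500 nM.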

Compound 4, half-maximal cytotoxic concentration: 3990 nM
Beside the measured number, compound 4's estimate is 1.3-fold (0.12 log units) below it; low and high end bracket the measured number.
By their numbers in this assay, from the lowest: compound 2; then compounds 1, 4 and 3 (each within the scatter of the next).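

At the place ortho to a large group on the pendant ring, this assay does not separate chloro from trifluoromethyl (a 1.1-fold lower number from compound 3 to compound 4 (0.02 log units; within the scatter)), even though chloro has 1 heavy atom and trifluoromethyl has 4. Replacing methoxy at this place with chloro gives a step beyond the scatter (a 4.2-fold higher number from compound 2 to compound 4 (0.63 log units; beyond the scatter)), and the earlier step to trifluoromethyl also lay beyond it, so among the three compounds with a group at this place, compound 2 alone stands apart, while the step from the 4-methoxyphenyl compound (a 1.4-fold higher number from compound 1 to compound 4 (0.14 log units; within the scatter)) leaves 2-chlorophenyl and 4-methoxyphenyl unseparated. Nothing available explains why methoxy stands apart from chloro and trifluoromethyl at this place.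

Open, going by these compounds, is whether the similarity of chloro and trifluoromethyl extends to other groups at this place, such as an amine, a carboxylic acid or a longer alkyl chain, or whether these would fall nearer to methoxy. Also open is how a chloro elsewhere on the pendant ring would read, since 4-chlorophenyl and 3-chlorophenyl analogues do not appear among the compounds shown.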